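The source may report more compounds than this note shows. Statements on the series, on what has been measured and on what is new or still open speak of the compounds shown alone.

Of the compounds shown here, two of a shared core have been measured. Compound 1, `N#Cc1ccc2c(c1)C(c1cccc[n+]1[O-])=CC(CF)(CF)O2`, gives in a functional assay on the whole organism (aorta) with Rattus norvegicus as the target (on this read-out higher numbers stand for larger maximal responses and lower numbers for smaller maximal responses), a value of 71.1%. Compound 2, `O=[N+]([O-])c1ccc2c(c1)C(c1cccc[n+]1[O-])=CC(CF)(CF)O2`, carries a nitro in place of the cyano on an aromatic carbon, and in this assay compound 2 gives 66.3%. Among the compounds with values here, the step of a number 4.8 percentage points lower from compound 1 to compound 2 (within the scatter) lies within the scatter, so the two numbers for compound 1 and compound 2 cannot be told apart, and compound 2 stands level with the only other compound of the set.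

Compound 3, `CS(=O)(=O)[N-][n+]1ccccc1C1=CC(CF)(CF)Oc2ccc([N+](=O)[O-])cc21`, differs from compound 2 at another place: a group of 5 heavy atoms (1 carbon, 1 nitrogen, 2 oxygen, 1 sulfur; no ring) in place of one oxygen atom, on an aromatic nitrogen

Within the data shown here, no measured step touches this change. Among the measured compounds shown here, the one step that has been measured, from compound 1 to compound 2, concerns a substituent on an aromatic carbon and says nothing about the aromatic nitrogen. The expectation for compound 3 therefore rests on compound 2 alone, which gave 66.3%, and the expected step of a number 6.3 percentage points lower from compound 2 to compound 3 (within the scatter) is a guess with a wide range in both directions. For compound 3 the estimated value in this assay is 60%, expected to fall between 35% and 85%.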

Compound 3, intrinsic activity: the largest response reached, in percent of the reference agonist's: 74.2%
Beside the measured number, compound 3's estimate is 14.2 percentage points below it, and the stated range covers the measured number.
By their numbers in this assay, from the lowest: compounds 2, 1 and 3 (each within the scatter of the next).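

In this assay, the exchange on the aromatic nitrogen of the six-membered aromatic ring, a group of 5 heavy atoms in place of one oxygen atom, gives a number 7.9 percentage points higher from compound 2 to compound 3 (within the scatter). Within the data shown here, this is the first reading at this position, and it shows that the maximal response of the series does not depend on keeping the single oxygen there: a much larger group with sulfur and a further nitrogen, carrying the same net charge of -1, leaves compound 3 level with compound 2 on this read-out. Nothing available on these compounds accounts for this outcome, so the finding stands as an observation only.

The compounds shown leave open how far this holds on the aromatic nitrogen, for instance whether an acetyl group or a longer chain on the sulfonyl group, such as ethyl or phenyl in place of its methyl, would also stay level with compound 2. They also leave open whether the same group on the aromatic nitrogen would behave alike in a compound carrying the nitrile of compound 1 instead of the nitro group.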